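Methyl on the phenoxy ring, carried across two cores

The compounds below may be only part of what the source reports. "The series", "measured", "known", "first", "only" and "open" are said of these compounds alone.

Compound 1 `N#Cc1c(Oc2ccccc2)sc(C(=O)c2ccc([N+](=O)[O-])cc2)c1N` and compound 2 `Cc1cccc(Oc2sc(C(=O)c3ccc([N+](=O)[O-])cc3)c(N)c2C#N)c1` share one core; compound 3 `N#Cc1sc(Oc2ccccc2)c(C#N)c1N` and compound 4 `Cc1cccc(Oc2sc(C#N)c(N)c2C#N)c1` share another. The difference between the two cores is not broken down here. In a physicochemical assay for lipophilicity (on this read-out lower numbers stand for lower lipophilicity and higher numbers for higher lipophilicity), compound 1 gives 4.53 and compound 2 gives 5.03. The change between them, (methyl in place of hydrogen on an aromatic carbon), made a step of a number 0.50 log units higher from compound 1 to compound 2 (beyond the scatter). In this assay compound 3 gives 2.54, the lowest of the three measured values, and its nearest measured neighbour is compound 1. Compound 4 carries the same change on the other core, (methyl in place of hydrogen on an aromatic carbon), and the place is described in the same words, so it is taken as the same change. Among the compounds with values here, the step from compound 3 to compound 4 is expected to be a number 0.50 log units higher from compound 3 to compound 4 (beyond the scatter), which rests on the single measured instance because the step of a number 0.50 log units higher from compound 1 to compound 2 (beyond the scatter) is the only precedent and no second instance on either core is available. Compound 4 is therefore expected to give 3.04 in this assay, with a range from 2.7 to 3.4 allowing for transfer across cores.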

Compound 4, partition coefficient: 3.04
Estimate against measurement, compound 4: no gap at the digits printed, and the stated range covers the measured number.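

In this assay, methyl in place of hydrogen on an aromatic carbon gives a number 0.50 log units higher from compound 3 to compound 4 (beyond the scatter), and on the other core the same change gives a number 0.50 log units higher from compound 1 to compound 2 (beyond the scatter); the two steps print the same size, and neither pair goes against it. This shows that, for these two pairs, the step carries from one core to the other without a visible change in size, which supports reading it as additive within the listed compounds but sets no rule for the series. It does not show that the agreement extends to a third core or to another place on the ring, and nothing available bears on why the step is the same on both cores.

The compounds shown leave open whether a larger or different group in the same place, such as ethyl, a longer chain, an amine or a carboxylic acid, would also give matching steps on the two cores. They also leave open whether methyl elsewhere on the six-membered aromatic ring would behave as this one does.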